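A fluorophenyl replaces the methylpyridyl group

The source may hold more compounds than are shown below. What is called first, only, known or untested is meant among the compounds shown, and "the series" means these compounds.

Among the compounds with values here, compound 2 `CCN(CCn1ccc(-c2cccc(C)n2)n1)C(=O)c1cc(C)ccc1-n1nccn1` gives 1.96 nM in a functional assay on CHO cells for antagonist activity at Orexin receptor type 2 (Homo sapiens), read by fluorescence and calcium flux, with a stated time of 30 min (on this read-out lower numbers stand for stronger inhibition and higher numbers for weaker inhibition), the lowest of the two numbers measured so far; the nearest is compound 1 `CCN(CCn1ccc(-c2ccc(C(F)(F)F)cn2)n1)C(=O)c1cc(C)ccc1-n1nccn1`, which in this assay gives 902 nM. Within the data shown here, the single measured step, a 460-fold lower number from compound 1 to compound 2 (2.66 log units; beyond the scatter), shows how strongly the group on the five-membered aromatic ring with 2 nitrogen can move the read-out. Compound 3 `CCN(CCn1ccc(-c2ccc(F)cc2)n1)C(=O)c1cc(C)ccc1-n1nccn1` carries 4-fluorophenyl in place of 6-methylpyridin-2-yl on an aromatic carbon. Among the measured compounds shown here, no measured step covers this exchange: the known step swaps one pyridyl group for another, whereas here the ring nitrogen and the methyl leave together and a six-membered aromatic ring of carbon only with a fluorine enters. Since compound 1 gives 902 nM against 1.96 nM for compound 2, a noticeable loss appears possible. The expected step is a 15-fold higher number from compound 2 to compound 3 (1.18 log units; beyond the scatter), a moderate rise in the number. Compound 3 is therefore estimated at 30 nM, with a range from 5 nM to 300 nM.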

Compound 3, antagonist equilibrium constant: 1.25 nM
Beside the measured number, compound 3's estimate is 24-fold (1.38 log units) above it; measured number outside the range, below it.
By their numbers in this assay, from the lowest: compounds 3 and 2 (each within the scatter of the next); then compound 1.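

On this aromatic carbon, next to the ring nitrogen, the ring nitrogen and the methyl of the 6-methylpyridin-2-yl group can leave together for 4-fluorophenyl with no change beyond the scatter: a 1.6-fold lower number from compound 2 to compound 3 (0.20 log units; within the scatter). A ring nitrogen is therefore not needed at this position for a low number among these compounds, and the high number of compound 1 is not shared by the carbon-only ring, as a 720-fold lower number from compound 1 to compound 3 (2.86 log units; beyond the scatter) shows. No measurement given here explains why these groups differ so widely.

From the compounds shown here alone, it remains open whether the high number follows the trifluoromethyl group itself, which a phenyl ring bearing trifluoromethyl would test. Also open, going by these compounds, is how an amine or a carboxylic acid in place of the fluorine would read in this assay.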